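The compounds below may be only part of what the source reports. "The series", "measured", "known", "first", "only" and "open" are said of these compounds alone.

Compound 1 `CCOC(=O)C1=Cc2ccccc2OC1(OCc1cn(-c2ccc(F)c([N+](=O)[O-])c2)nn1)C(F)(F)F` gives 16200 nM in a functional assay on MCF7 cells (Homo sapiens) for inhibition, read by MTT assay, with a stated time of 24 h; on this read-out lower numbers stand for stronger inhibition and higher numbers for weaker inhibition. Compound 2 `CCOC(=O)C1=Cc2ccccc2OC1(OCc1cn(CC(=O)Nc2cccc(F)c2)nn1)C(F)(F)F` reaches only > 150000 nM, which is a limit of this assay and not a number.

Compound 2 thus sits at the weak end of the two values shown, and only a limit is known for it (the limit of > 150000 nM in this assay, at which 1 of the 2 values shown sits). Compound 3 `CCOC(=O)C1=Cc2ccccc2OC1(OCc1cn(-c2ccc(C)cc2)nn1)C(F)(F)F` differs from compound 2 by 4-methylphenyl in place of ((3-fluorophenyl)carbamoyl)methyl on an aromatic nitrogen. Among the measured compounds shown here, the one measured step at this place, an at least 9.2-fold higher number from compound 1 to compound 2 (0.96 log units; beyond the scatter), ran the other way: 4-fluoro-3-nitrophenyl gave way to ((3-fluorophenyl)carbamoyl)methyl and the number rose. Returning to a phenyl group on the ring nitrogen is therefore expected to bring the number back down, roughly reversing that step, with an at least 7.5-fold lower number from compound 2 to compound 3 (0.87 log units; beyond the scatter). Compound 3 is estimated at 20000 nM, between 6000 nM and 80000 nM.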

Compound 3, half-maximal inhibitory concentration: 26700 nM
Beside the measured number, compound 3's estimate is 1.3-fold (0.13 log units) below it; the measured number falls inside the stated range.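

Moving from ((3-fluorophenyl)carbamoyl)methyl to 4-methylphenyl gives an at least 5.6-fold lower number from compound 2 to compound 3 (0.74 log units; beyond the scatter). Compound 2 has only a limit and not a number: the limit of > 150000 nM in this assay, at which 1 of the 3 values shown sits. Compound 3 then adds a second phenyl group to the comparison, with a 1.6-fold higher number from compound 1 to compound 3 (0.22 log units; within the scatter), so in this assay 4-methylphenyl and 4-fluoro-3-nitrophenyl cannot be told apart, and the nitro and fluoro substituents are not needed to stay in this range.

The compounds shown leave open whether the ring attached directly to the aromatic nitrogen or the loss of the amide accounts for the step. On these data alone, how a benzyl group or a carboxylic acid at this position would read also remains open.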